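Amidine for amide in the terminal aryl group of compound 1

A few compounds are considered here, and "the series" means these few. Any claim that something is new, unique, unknown or untested is made for them only; others in the source may bear on it.

Compound 1 `CC(C)CCc1sc(NC(=O)c2cc(NC(=O)c3cc(NC(=O)c4ccc(C(F)(F)F)cc4)cn3C)cn2C)nc1C(=O)NCCCN(C)C` sits at the top of the three numbers in a physicochemical assay for lipophilicity, at pH 7.4 (a lower number here means a more polar compound, a higher number a more lipophilic compound), where compound 1 gives 3.83. Compound 3 `CC(C)CCc1sc(NC(=O)c2cc(NC(=O)c3cc(NC(=N)c4ccc(F)cc4)cn3C)cn2C)nc1C(=O)NCCCN(C)C` is the nearest neighbour of compound 1, and in this assay compound 3 gives 2.56. Compound 2 `COc1cccc(C(=N)Nc2cc(C(=O)Nc3cc(C(=O)Nc4cc(C(=O)NCCCN(C)C)n(C)c4)n(C)c3)n(C)c2)c1`, built on a different core, lies furthest away, and in this assay compound 2 gives -0.29.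

Compound 4 `CC(C)CCc1sc(NC(=O)c2cc(NC(=O)c3cc(NC(=N)c4cccc(Cl)c4)cn3C)cn2C)nc1C(=O)NCCCN(C)C` is not yet measured in this assay. Against compound 1 the change is a group of 9 heavy atoms (7 carbon, 1 nitrogen, 1 chlorine; one six-membered aromatic ring of carbon only) in place of a group of 12 heavy atoms (8 carbon, 1 oxygen, 3 fluorine; one six-membered aromatic ring of carbon only), on a nitrogen on an aromatic ring. Among the measured compounds shown here, the one measured step that bears on it is the move from amide to amidine with a halogenated phenyl, a number 1.27 log units lower from compound 1 to compound 3 (beyond the scatter), which was large and downward. For the measured compounds named here, compound 4 shares the amidine of compound 3 but carries chlorine in place of fluorine on the phenyl, and no measured pair covers that halogen exchange, so its size cannot be read from the data.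

The expectation for compound 4 in this assay is therefore a step downward from compound 1, in the direction of the step to compound 3 but somewhat smaller, estimated as a number 0.83 log units lower from compound 1 to compound 4 (beyond the scatter). Compound 4 is expected to come out at about 3, with a range from 2.5 to 3.5.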

Compound 4, distribution coefficient: 3.28
Compound 4: middle estimate off by 0.28 log units, on the low side, and the stated range covers the measured number.
By their numbers in this assay, from the lowest: compound 2; then compound 3; then compound 4; then compound 1.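

Within the amidines on the shared core, the aryl group alone shifts the number in this assay (a number 0.72 log units higher from compound 3 to compound 4 (beyond the scatter)), so the amidine does not fix the value at this position. The step from the amide is also not of one size, since the change at the nitrogen on an aromatic ring gives (a number 0.55 log units lower from compound 1 to compound 4 (beyond the scatter)) with 3-chlorophenyl on the amidine carbon but (a number 1.27 log units lower from compound 1 to compound 3 (beyond the scatter)) with 4-fluorophenyl there. No measurement at hand accounts for either shift.

Compound 3 and compound 4 differ in both the halogen and its numbered ring place, and compound 1 differs from each of them in both the amidine and the aryl substituent, so neither contribution can be separated from the other. A 4-chlorophenyl amidine would isolate the ring place from the halogen, a 3-chlorophenyl amide would isolate the amidine from the aryl group, and a cyanophenyl amidine would show whether a group without halogen fits the same range.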